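Pyridin-3-yl for pyridin-2-yl: lipophilicity of compound 3

The source may report more compounds than this note shows. Statements on the series, on what has been measured and on what is new or still open speak of the compounds shown alone.

Measured so far:
compound 1 `Cc1ncc(-c2cc(NC(=O)c3ccc(OCc4ccccn4)cc3)c(C)cc2C)[nH]1` gives 2.8 in a physicochemical assay for lipophilicity; a higher number here means a more lipophilic compound, a lower number a more polar compound
compound 2 `Cc1cc(C)c(-c2ccccn2)cc1NC(=O)c1ccc(OCc2ccccn2)cc1` gives > 3 in this assay

Compound 2 stands at a limit of this assay, not at a number (the limit of > 3 in this assay, at which 1 of the 2 values shown sits). Among the compounds with values here, the single measured step, a number at least 0.20 log units higher from compound 1 to compound 2 (that floor lies within the scatter), exchanges a different ring and bears only loosely on the change to compound 3 `Cc1cc(C)c(-c2cccnc2)cc1NC(=O)c1ccc(OCc2ccccn2)cc1`, which is pyridin-3-yl in place of pyridin-2-yl on an aromatic carbon. Within the data shown here, no step between two pyridyl isomers has been measured. Compound 3 is therefore expected to show a step of a number no higher from compound 2 to compound 3 (the limit leaves the size open) that stays within the scatter. The estimate for compound 3 in this assay is 3, ranging from 2.6 to 3.4.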

Compound 3, distribution coefficient: > 3
Compound 3: only a limit was reported; the forecaster's own chance of this, stated with the estimate: 45%; the middle value sits exactly at the limit.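

In this assay compound 3 gives > 3, a limit of the assay and not a number. The step between the two pyridyl isomers cannot be read, because both compounds sit at this limit: the limit of > 3 in this assay, at which 2 of the 3 values shown sit. Pyridin-3-yl in place of 2-methyl-1H-imidazol-5-yl gives a number at least 0.20 log units higher from compound 1 to compound 3 (that floor lies within the scatter), the same floor as printed for pyridin-2-yl.

From the compounds shown here alone, how far either pyridyl compound lies past the limit remains open, and so does whether the two isomers differ at all. Going by these compounds, what pyridin-4-yl or a carboxylic acid at this position would give in this assay is also open.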